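This account rests on a few compounds, and the source may have more. Where it says the series, first, only, none or still open, it means among the compounds named here.

Compound 3 (`O=C(CO)NC[C@@H]1CCCc2cc(S(=O)(=O)c3cccc(F)c3)ccc21`) stands at the strong end of the three compounds measured in an assay on isolated protein for displacement of a labelled ligand from 5-hydroxytryptamine receptor 6 (Homo sapiens) (on this read-out lower numbers stand for stronger inhibition and higher numbers for weaker inhibition), where compound 3 gives 0.1 nM. Compound 1 (`CN(C[C@@H]1CCCc2cc(S(=O)(=O)c3cccc(F)c3)ccc21)S(N)(=O)=O`) gives 3.98 nM in this assay, and compound 2 (`O=C(NC[C@@H]1CCCc2cc(S(=O)(=O)c3cccc(F)c3)ccc21)c1ccc[nH]1`) gives 5.01 nM. The step of a 1.3-fold higher number from compound 1 to compound 2 (0.10 log units; within the scatter) is small, whereas the steps of a 40-fold lower number from compound 1 to compound 3 (1.60 log units; beyond the scatter) and a 50-fold lower number from compound 2 to compound 3 (1.70 log units; beyond the scatter) are both large, so compound 3 is the most potent of the three.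

Compound 4 (`CC(C)(O)C(=O)NC[C@@H]1CCCc2cc(S(=O)(=O)c3cccc(F)c3)ccc21`) differs from compound 3 by 1-hydroxy-1-methylethyl in place of hydroxymethyl on a carbonyl carbon. For the measured compounds named here, the only measured step at the carbonyl carbon, a 50-fold lower number from compound 2 to compound 3 (1.70 log units; beyond the scatter), replaced a ring with the hydroxymethyl group that compound 4 keeps, so it offers no direct precedent for adding two methyl groups there. With the hydroxy group retained, the expected step of a 3.2-fold higher number from compound 3 to compound 4 (0.51 log units; beyond the scatter) is modest, most likely a slightly higher number. Compound 4 is therefore estimated at 0.32 nM in this assay. The expected range for compound 4 runs from 0.08 nM to 1.3 nM.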

Compound 4, inhibition constant: 2 nM
Estimate against measurement, compound 4: 6.3-fold (0.80 log units) below, outside the stated range (above it).
By their numbers in this assay, from the lowest: compound 3; then compounds 4, 1 and 2 (each within the scatter of the next, the first and the last beyond it).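

At this place on a carbonyl carbon, the hydroxy group alone does not preserve the strength of compound 3: in this assay the change to 1-hydroxy-1-methylethyl gives a 20-fold higher number from compound 3 to compound 4 (1.30 log units; beyond the scatter) even though the hydrogen-bond donor and acceptor counts stay the same. Against the 1H-pyrrol-2-yl group, the advantage left is a 2.5-fold lower number from compound 2 to compound 4 (0.40 log units; beyond the scatter) and the comparison with the methyl(sulfamoyl)amino group gives a 2.0-fold lower number from compound 1 to compound 4 (0.30 log units; within the scatter) so most of what set hydroxymethyl apart from both is lost. Nothing shown here accounts for the size of this loss.

On these data alone, it remains open whether a single added methyl, as in 1-hydroxyethyl, would already carry the loss. Also open, as far as these compounds go, is whether an aminomethyl or methoxymethyl group on the same carbonyl carbon would match hydroxymethyl.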